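The source may report more compounds than this note shows. Statements on the series, on what has been measured and on what is new or still open speak of the compounds shown alone.

Working notes on the series

The shared core of compound 1 `COc1ccc(C(=O)c2cc(OC)c(OC)c(OC)c2)cc1N` carries a free amine, and in a functional assay on B16 cells (Mus musculus) for cytotoxicity, read by MTT assay, with a stated time of 72 h (on this read-out lower numbers stand for stronger inhibition and higher numbers for weaker inhibition), compound 1 gives 30 nM. The amide compound 2 `COc1ccc(C(=O)c2cc(OC)c(OC)c(OC)c2)cc1NC(=O)/C=C/c1ccc(OC)c(OC)c1` is far weaker: in this assay compound 2 gives 6300 nM. Compound 3 `COc1cccc(/C=C/C(=O)Nc2cc(C(=O)c3cc(OC)c(OC)c(OC)c3)ccc2OC)c1` differs from it by hydrogen in place of methoxy on an aromatic carbon, and in this assay compound 3 gives 3100 nM; the step of a 2.0-fold lower number from compound 2 to compound 3 (0.31 log units; beyond the scatter) is modest. Compound 3 thus stands second highest of the three numbers, nearest to compound 2 and furthest from compound 1, whose number is much lower.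

Compound 4 `COc1ccc(C(=O)c2cc(OC)c(OC)c(OC)c2)cc1NC(=O)/C=C/c1cccc(OC(F)(F)F)c1` is not yet measured. It differs from compound 3 by trifluoromethyl in place of methyl on an oxygen on an aromatic ring. Among the measured compounds shown here, no measured step alters a substituent on this oxygen; the only step in the amide part, a 2.0-fold lower number from compound 2 to compound 3 (0.31 log units; beyond the scatter), removed a methoxy altogether and was modest, so it gives no firm direction. For compound 4 the expected step is a 1.0-fold lower number from compound 3 to compound 4 (0.01 log units; within the scatter) in this assay, not beyond the scatter. The estimate for compound 4 is 3000 nM, within a range from 1000 nM to 10000 nM.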

Compound 4, half-maximal inhibitory concentration: 6300 nM
Compound 4: middle estimate off by 2.1-fold (0.32 log units), on the low side, within the range that was stated.
By their numbers in this assay, from the lowest: compound 1; then compound 3; then compounds 2 and 4 (each within the scatter of the next).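

Trifluoromethyl in place of methyl on this oxygen has a modest effect in this assay (a 2.0-fold higher number from compound 3 to compound 4 (0.31 log units; beyond the scatter)); this is the first step that changes what the oxygen carries rather than removing the methoxy, and it runs opposite to the earlier step from compound 2 to compound 3. Putting 3-(trifluoromethoxy)phenyl in place of 3,4-dimethoxyphenyl on the double-bonded chain carbon leaves the number in place (no change at the digits printed from compound 2 to compound 4 (within the scatter)), so the amides shown differ from one another by modest steps at most. Nothing at hand explains either step.

With a single replacement on this oxygen, one step cannot show whether the fluorine atoms or some other feature of the change set its size. As far as these compounds go, how a longer chain such as ethyl on the oxygen, or an amine in place of the methoxy, would read in this assay remains open.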